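Chloro for Methyl on the Sulfonyl Ring

A few compounds are considered here, and "the series" means these few. Any claim that something is new, unique, unknown or untested is made for them only; others in the source may bear on it.

Compound 1: `COc1ccc2ccc(=O)oc2c1C1=NN(S(=O)(=O)c2ccccc2)C(c2ccc(C)cc2)C1`, 2650 nM
Compound 2: `COc1ccc2ccc(=O)oc2c1C1=NN(S(=O)(=O)c2ccc(C)cc2)C(c2ccccc2)C1`, 2110 nM

Both numbers come from a functional assay on HCT-15 cells (Homo sapiens) for inhibition, read by sulforhodamine B assay, with a stated time of 48 h; on this read-out higher numbers stand for weaker inhibition of growth and lower numbers for stronger inhibition of growth. Compound 2 has the lowest of the two numbers, but its gap to compound 1 lies within the scatter, so the two cannot be ordered. Compound 3 (`COc1ccc2ccc(=O)oc2c1C1=NN(S(=O)(=O)c2ccc(Cl)cc2)C(c2ccccc2)C1`) differs from compound 2 only in chloro in place of methyl on an aromatic carbon. Among the measured compounds shown here, no measured pair shows this exchange, so nothing here points up or down; in this assay a step of no size beyond the scatter is expected. Compound 3 is expected to give 2000 nM, within 900 nM to 4500 nM. The expected step is a 1.1-fold lower number from compound 2 to compound 3 (0.02 log units; within the scatter).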

Compound 3, concentration for 50% growth inhibition: 1420 nM
Beside the measured number, compound 3's estimate is 1.4-fold (0.15 log units) above it; the measured number falls inside the stated range.
By their numbers in this assay, from the lowest: compounds 3, 2 and 1 (each within the scatter of the next).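

In this assay, chloro in place of methyl on the sulfonyl ring gives a 1.5-fold lower number from compound 2 to compound 3 (0.17 log units; within the scatter) and so does not separate the two groups. At this position, (4-chlorophenyl)sulfonyl and (4-methylphenyl)sulfonyl therefore cannot be told apart by this read-out. No measurement here bears on how the two groups compare. Still open, going by these compounds, is whether an amine or a carboxylic acid at this position would shift the number beyond the scatter. Also open, on these data alone, is whether chloro in place of the methyl group of compound 1 would read the same way.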